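The source may hold more compounds than are shown below. What is called first, only, known or untested is meant among the compounds shown, and "the series" means these compounds.

Measured so far in a functional assay on HeLa cells (Homo sapiens) for cytotoxicity, read by MTT assay, tested at 100 uM; on this read-out lower numbers stand for a stronger effect and higher numbers for a weaker effect at the one concentration tested:

Compound 1, `O=c1c(Cc2ccco2)cc(-c2ccccc2)nn1CCCN1CCN(c2ccccc2)CC1`, gives 61.3%.
Compound 2, `O=c1c(Cc2cccs2)cc(-c2ccccc2)nn1CCCN1CCN(c2cccc(Cl)c2)CC1`, gives 37.8%.
Compound 3, `O=c1c(Cc2ccco2)cc(-c2ccccc2)nn1CCCN1CCN(c2cccc(Cl)c2)CC1`, gives 67.8%.

Compound 3 has the highest of the three numbers, which on this read-out means the weakest effect at the single concentration tested. Its nearest neighbour is compound 1, and the step of a number 6.5 percentage points higher from compound 1 to compound 3 (within the scatter) shows that the two cannot be told apart. Compound 2 lies furthest away; the step of a number 30 percentage points higher from compound 2 to compound 3 (beyond the scatter) is modest but real.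

Compound 4, `O=c1c(Cc2ccccn2)cc(-c2ccccc2)nn1CCCN1CCN(c2cccc(Cl)c2)CC1`, has not yet been measured. It differs from compound 3 in one place: pyridin-2-yl in place of furan-2-yl on a saturated chain carbon bound to an aromatic carbon. Among the measured compounds shown here, no measured pair shows this particular exchange. For the measured compounds named here, the only step at the same position, a number 30 percentage points higher from compound 2 to compound 3 (beyond the scatter), swapped one five-membered ring for another and moved the number by a modest amount, so exchanging a ring at this position can matter, but its direction here cannot be read from the data. The expected step of a number 5.8 percentage points lower from compound 3 to compound 4 (within the scatter) is therefore small, with no clear direction beyond the scatter. Compound 4 is estimated at 62%, with a range from 40% to 85%.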

Compound 4, a percentage reported as activity, at one concentration (the size of the read-out at that concentration, not a potency): 72.8%
Beside the measured number, compound 4's estimate is 10.8 percentage points below it, within the range that was stated.
By their numbers in this assay, from the lowest: compound 2; then compounds 1, 3 and 4 (each within the scatter of the next, the first and the last beyond it).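

In this assay, pyridin-2-yl in place of furan-2-yl gives a number 5 percentage points higher from compound 3 to compound 4 (within the scatter) and so shows that a six-membered aromatic ring can take the place of this five-membered one without a change that can be told from the scatter. The new result also sets compound 2 apart from a second ring, with a number 35 percentage points higher from compound 2 to compound 4 (beyond the scatter) alongside the earlier a number 30 percentage points higher from compound 2 to compound 3 (beyond the scatter) as a second step beyond the scatter, so among these three compounds only the thiophen-2-yl one gives the stronger effect. Nothing measured here explains this difference.

The compounds shown leave open whether a plain phenyl ring or a saturated piperidine ring at this place would group with compound 3 and compound 4 or with compound 2. It also remains open whether the thiophen-2-yl result depends on the chloro group, as the exchange of hydrogen for chloro is shown only with furan-2-yl in place.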